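The source may report more compounds than this note shows. Statements on the series, on what has been measured and on what is new or still open speak of the compounds shown alone.

Compound 1 `COc1ccc2c(c1)CC(c1nc3ccc(-c4ccnc(N)n4)cc3[nH]1)CO2`: 2.3 h
Compound 2 `Nc1nccc(-c2ccc3nc(C4COc5c(cccc5C(=O)NC5CC5)C4)[nH]c3c2)n1`: 2 h

In an in vivo ADME assay on the whole organism for metabolic stability, with Rattus norvegicus as the target (a lower number here means that the compound disappears faster, a higher number that the compound lasts longer), compound 1 gives 2.3 h and compound 2 gives 2 h. These two values lie within the usual scatter of repeated measurements, so compound 1 stands level with compound 2 on the numbers available.

Compound 3 `CN(C)CCCNC(=O)c1ccc2c(c1)CC(c1nc3ccc(-c4ccnc(N)n4)cc3[nH]1)CO2` keeps the core of compound 1 but carries (3-(dimethylamino)propyl)carbamoyl in place of methoxy on an aromatic carbon. Among the compounds with values here, the data contain no step between two measured compounds that differ in one place, so they do not show how this assay responds to a change of this kind. Within the data shown here, the only guide is the pair of close values, with compound 1 at 2.3 h and compound 2 at 2 h. With no measured evidence for a direction, the expectation stays close to those numbers, and no shift beyond the scatter is expected. The estimated change is a 1.1-fold higher number from compound 1 to compound 3 (0.04 log units; within the scatter). As far as these compounds go, the uncertainty is wide, since the new group is untested here. For compound 3 the estimated half-life is 2.5 h, with an expected range of 1 h to 6 h.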

Compound 3, half-life: 3 h
Compound 3: middle estimate off by 1.2-fold (0.08 log units), on the low side, and the stated range covers the measured number.
By their numbers in this assay, from the lowest: compounds 2, 1 and 3 (each within the scatter of the next).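

Within the data shown here, this is the first step between two measured compounds that differ in one place. It concerns an aromatic carbon that is meta to a fused ring and para to a fused ring: in this assay, (3-(dimethylamino)propyl)carbamoyl in place of methoxy gives a 1.3-fold higher number from compound 1 to compound 3 (0.12 log units; within the scatter). Here, then, methoxy with 2 heavy atoms can give way to an open chain group with 9 heavy atoms and a hydrogen-bond donor, and the half-life stays level with that of compound 1. The data offer no measurement that would explain this outcome.

The compounds shown leave open whether a carboxylic acid, a plain primary amide or a longer chain ending in a morpholine ring at this position would also stay level in this assay. With a single step at this position, it also remains unresolved what the amide and the dimethylamino end each contribute, and whether either part alone would give a similar half-life.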